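Swapping a Formylphenyl Arm for Naphthyl

The compounds below may be only part of what the source reports. "The series", "measured", "known", "first", "only" and "open" are said of these compounds alone.

Of the compounds shown here, two have been measured in a physicochemical assay for lipophilicity, using the shake flask method, in phosphate buffer, measured as octanol-water partition, with a stated time of 85 min, at pH 7.4; on this read-out lower numbers stand for lower lipophilicity and higher numbers for higher lipophilicity. Compound 1 `c1ccc2c(-c3cn4ccnc4c(-c4ccc5ncn(C6CCCCC6)c5c4)n3)cccc2c1` gives 1.44. Compound 2 `O=Cc1ccc(-c2cn3ccnc3c(-c3ccc4ncn(Cc5ccccc5)c4c3)n2)cc1` gives 1.88, the higher of the two numbers, standing above compound 1 by a gap beyond the usual scatter. Compound 3 `c1ccc(Cn2cnc3ccc(-c4nc(-c5cccc6ccccc56)cn5ccnc45)cc32)cc1` is not yet measured; it differs from compound 2 in one place: naphthalen-1-yl in place of 4-formylphenyl on an aromatic carbon. Within the data shown here, no measured pair isolates this change, so the expectation rests on the change itself. Compound 3 is expected to move upward by a number 0.82 log units higher from compound 2 to compound 3 (beyond the scatter), a step beyond the scatter. Compound 3 is therefore estimated at 2.7, within a range from 2.1 to 3.3.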

Compound 3, partition coefficient: 2
Compound 3: the middle estimate sits 0.70 log units above what was measured; measured number outside the range, below it.
By their numbers in this assay, from the lowest: compound 1; then compounds 2 and 3 (each within the scatter of the next).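

In this assay, putting naphthalen-1-yl in place of 4-formylphenyl on this aromatic carbon gives a number 0.12 log units higher from compound 2 to compound 3 (within the scatter), so these two groups cannot be told apart here. Among these compounds, the other single change, benzyl in place of cyclohexyl on the aromatic nitrogen, gives a number 0.56 log units higher from compound 1 to compound 3 (beyond the scatter) and is the only step here that clearly separates two compounds. Nothing available explains either step.

As far as these compounds go, whether an amine or a carboxylic acid on that aromatic carbon would move the number remains open. So does the effect of a longer chain on the aromatic nitrogen.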